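This account rests on a few compounds, and the source may have more. Where it says the series, first, only, none or still open, it means among the compounds named here.

Compound 1 `O=S(=O)(NN1C(=S)S/C(=C\c2ccc(Cl)c(Cl)c2)C1O)c1ccc(Cl)cc1`: > 50000 nM
Compound 2 `O=C1/C(=C/c2ccc(Cl)c(Cl)c2)SC(=S)N1NS(=O)(=O)c1cccs1`: > 50000 nM
Compound 3 `O=C1/C(=C/c2ccc(C(F)(F)F)cc2)SC(=S)N1NS(=O)(=O)c1ccccc1`: > 50000 nM

These results come from a functional assay on ECV-304 cells (Homo sapiens) for cytotoxicity; on this read-out lower numbers stand for stronger inhibition and higher numbers for weaker inhibition. None of the three entries is a true number, and the whole picture so far is the limit of > 50000 nM in this assay, at which 3 of the 3 values shown sit. Compound 2 gives > 50000 nM, which is a limit of the assay and not a number.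

The next compound to be tested, compound 4 `O=C1/C(=C/c2ccc(Cl)c(Cl)c2)SC(=S)N1NS(=O)(=O)c1ccccc1`, differs from compound 2 by a single swap: phenyl in place of thiophen-2-yl on a sulfonyl sulfur. The counted difference is phenyl in place of thiophen-2-yl on a sulfonyl sulfur.

Among the compounds with values here, no pair of measured compounds shows what a change of this kind does in this assay. The expectation therefore rests on compound 3, which also carries phenyl on a sulfonyl sulfur and gives > 50000 nM, a limit of the assay. No step beyond the usual scatter is expected, and the estimated step is a number no higher from compound 2 to compound 4 (the limit leaves the size open). The estimate for compound 4 is 50000 nM, with an expected range of 20000 nM to 100000 nM.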

Compound 4, half-maximal inhibitory concentration: > 50000 nM
Compound 4: only a limit was reported; the forecaster's own chance of this, stated with the estimate: 85%; the middle value lies on the limit itself.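

Compound 2 and compound 4 are both reported only as limits and not as numbers, and no step can be read between them for phenyl in place of thiophen-2-yl on a sulfonyl sulfur. The compounds shown leave open what true value any of them has in this assay, and whether this swap changes it at all.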